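A few compounds are considered here, and "the series" means these few. Any claim that something is new, unique, unknown or untested is made for them only; others in the source may bear on it.

Measured in a functional assay on A549 cells (Homo sapiens) for inhibition, read by CCK-8 assay, with a stated time of 48 h; on this read-out higher numbers stand for weaker inhibition and lower numbers for stronger inhibition:
- Compound 1 `COc1cc(-c2ccnc3cc(-c4cn(CO)c5ccccc45)nn23)cc(OC)c1OC`: 167 nM
- Compound 2 `COc1cc(-c2ccnc3cc(-c4ccc(Cl)cc4)nn23)cc(OC)c1OC`: 3070 nM
- Compound 3 `COc1cc(-c2ccnc3cc(-c4ccc(C)c(C)c4)nn23)cc(OC)c1OC`: 272 nM

Compound 3, at 272 nM, lies within the usual scatter of compound 1, and both values are far lower than that of compound 2. The next compound, compound 4 `COc1cc(-c2ccnc3cc(-c4ccc5c(ccn5C)c4)nn23)cc(OC)c1OC`, keeps the shared core and changes one group: 1-methyl-1H-indol-5-yl in place of 3,4-dimethylphenyl on an aromatic carbon.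

Among the measured compounds shown here, only one measured step bears directly on this place: an 11-fold lower number from compound 2 to compound 3 (1.05 log units; beyond the scatter). It shows that the group here can shift the number strongly, but it involves a different pair of groups and so gives no direction for this change. The closest guide is compound 1, which also carries a fused two-ring group at this place and gives 167 nM. A small step toward a lower number in this assay is therefore expected, and the expected step is a 2.3-fold lower number from compound 3 to compound 4 (0.36 log units; beyond the scatter). For compound 4 the estimated value is 120 nM, with an expected range from 25 nM to 500 nM.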

Compound 4, half-maximal inhibitory concentration: 15 nM
The estimate for compound 4 lay 8.0-fold (0.90 log units) above the measured number, outside the stated range (below it).
By their numbers in this assay, from the lowest: compound 4; then compounds 1 and 3 (each within the scatter of the next); then compound 2.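

In (this assay), 1-methyl-1H-indol-5-yl at this place gives a large gain over both single-ring groups (an 18-fold lower number from compound 3 to compound 4 (1.26 log units; beyond the scatter); a 200-fold lower number from compound 2 to compound 4 (2.31 log units; beyond the scatter)). Among the compounds shown here, the earlier step showed only that one single-ring group could differ strongly from another, whereas this result shows that this place on the five-membered aromatic ring with 2 nitrogen can carry a larger group of two fused rings and reach a much lower number. Two fused rings alone do not settle the value, since compound 1 also has them and gives (167 nM), while compound 4 gives (15 nM).

Nothing shown explains this gain. On these data alone, it also remains open whether the number stays this low with a longer chain, such as propyl, in place of the methyl, or with a carboxylic acid on the fused rings.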